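Five-membered heteroaryl variation on the piperazine methylene

The source may hold more compounds than are shown below. What is called first, only, known or untested is meant among the compounds shown, and "the series" means these compounds.

Measured compounds:
compound 1 `Cc1ccc(CN2CCN(c3cccc4[nH]c(-c5ccc(C(C)(C)C)cc5)nc34)CC2)o1` 705 nM
compound 2 `Cc1nc(CN2CCN(c3cccc4[nH]c(-c5ccc(C(C)(C)C)cc5)nc34)CC2)c[nH]1` 7.5 nM
compound 3 `CCc1nc(C)c(CN2CCN(c3cccc4[nH]c(-c5ccc(C(C)(C)C)cc5)nc34)CC2)s1` 20 nM

Within an assay on isolated protein for displacement of a labelled ligand from Gonadotropin-releasing hormone receptor (Homo sapiens) (on this read-out lower numbers stand for stronger inhibition and higher numbers for weaker inhibition), compound 3 stands second highest of the three numbers. Compound 2 is nearest, the step of a 2.7-fold higher number from compound 2 to compound 3 (0.43 log units; beyond the scatter) lying beyond the scatter; compound 1 is furthest, the step of a 35-fold lower number from compound 1 to compound 3 (1.55 log units; beyond the scatter) being large.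

Compound 4 `CCc1cc(CN2CCN(c3cccc4[nH]c(-c5ccc(C(C)(C)C)cc5)nc34)CC2)nn1C` is not yet measured. It differs from compound 3 by 5-ethyl-1-methyl-1H-pyrazol-3-yl in place of 2-ethyl-4-methyl-1,3-thiazol-5-yl on a saturated chain carbon bound to an amine nitrogen in a ring. Among the measured compounds shown here, only one earlier step swaps a five-membered heteroaryl with two hetero atoms for another such ring: a 2.7-fold higher number from compound 2 to compound 3 (0.43 log units; beyond the scatter), a modest step. The large steps of a 94-fold lower number from compound 1 to compound 2 (1.97 log units; beyond the scatter) and a 35-fold lower number from compound 1 to compound 3 (1.55 log units; beyond the scatter) both start from the furan of compound 1 and bear less directly on this change. The ring entering in compound 4 carries two nitrogens, as does the ring of compound 2, so a modest step in this assay toward a lower number is expected, though a result within the scatter of compound 3 would not surprise. The estimate for compound 4 in this assay is 14 nM with a range of 5 nM to 50 nM, which means an expected step of a 1.4-fold lower number from compound 3 to compound 4 (0.15 log units; within the scatter).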

Compound 4, half-maximal inhibitory concentration: 43 nM
Compound 4: the middle estimate sits 3.1-fold (0.49 log units) below what was measured, within the range that was stated.
By their numbers in this assay, from the lowest: compound 2; then compound 3; then compound 4; then compound 1.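

Working notes: in this assay, the exchange gives a 2.2-fold higher number from compound 3 to compound 4 (0.33 log units; beyond the scatter), so the two rings are distinguishable at this position even though the groups match in heavy-atom count, donors, acceptors and ring hetero atom count. Two ring nitrogens alone do not reproduce the result of the 2-methyl-1H-imidazol-4-yl group, as a 5.7-fold higher number from compound 2 to compound 4 (0.76 log units; beyond the scatter) shows, yet the 5-ethyl-1-methyl-1H-pyrazol-3-yl group retains a clear advantage over the furan, with a 16-fold lower number from compound 1 to compound 4 (1.21 log units; beyond the scatter). The data offer no measured basis for explaining these differences.

Open, on these data alone, is whether the hydrogen on the imidazole nitrogen matters, which a 1,2-dimethyl-1H-imidazol-4-yl group would address. The contribution of the ethyl chain on the pyrazole also remains unresolved, and a 1,5-dimethyl-1H-pyrazol-3-yl group would test it.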